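The compounds below may be only part of what the source reports. "The series", "measured", "known", "first", "only" and "open" are said of these compounds alone.

Compound 1 `COc1ncnc2c1c(-c1ccsc1)cn2[C@@H]1O[C@H](CO)[C@@H](O)[C@H]1O` holds the only number shown in a functional assay on A549 cells (Homo sapiens), read by MTT assay, with a stated time of 72 h; a lower number here means a stronger inhibitor, a higher number a weaker inhibitor: compound 1 gives 5170 nM. Compound 2 `CNc1ncnc2c1c(-c1ccsc1)cn2[C@@H]1O[C@H](CO)[C@@H](O)[C@H]1O` is reported in this assay only as a limit, > 20000 nM. Among the compounds with values here, the single measured step, an at least 3.8-fold higher number from compound 1 to compound 2 (0.58 log units; beyond the scatter), is itself bounded by the limit of > 20000 nM in this assay, at which 1 of the 2 values shown sits, so its true size is open-ended.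

Compound 3 `COc1ncnc2c1c(-c1ccco1)cn2[C@@H]1O[C@H](CO)[C@@H](O)[C@H]1O` carries the change (furan-2-yl in place of thiophen-3-yl on an aromatic carbon). This alteration sits at a different place from the methylamino for methoxy exchange, so no measured step bears on it and the one step shown cannot be carried over. Compound 3 is therefore expected to show no step beyond the scatter in either direction, a 1.2-fold higher number from compound 1 to compound 3 (0.06 log units; within the scatter). The estimate for compound 3 in this assay is 6000 nM, with a range from 2500 nM to 20000 nM; given that compound 2 is reported only as a limit, a limit rather than a number remains possible for compound 3 as well.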

Compound 3, half-maximal inhibitory concentration: 30 nM
Compound 3: the middle estimate sits 200-fold (2.30 log units) above what was measured; the whole stated range lies above it.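

In this assay, this aromatic carbon proves highly sensitive to which five-membered aromatic ring it carries: a 170-fold lower number from compound 1 to compound 3 (2.24 log units; beyond the scatter). The thiophen-3-yl and furan-2-yl groups match in the counts available, each with 5 heavy atoms, 1 hetero atom and 1 hydrogen-bond acceptor, so those counts do not separate compound 1 from compound 3. Nothing at hand gives a reason for the size of this step.

The change swaps sulfur for oxygen and also moves the point of attachment, so this one step cannot separate the two; thiophen-2-yl and furan-3-yl groups would bear on that question. From the compounds shown here alone, it also remains open whether furan-2-yl keeps this effect with methylamino in place of methoxy, and how a phenyl ring at this position would compare.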